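Swapping chloro for methoxy on a shared two-armed core

The source may hold more compounds than are shown below. What is called first, only, known or untested is meant among the compounds shown, and "the series" means these compounds.

Of the compounds shown here, two of one shared core have been measured in a functional assay on U-87MG ATCC cells for antiproliferative activity against U-87 MG (Homo sapiens), read by MTT assay, with a stated time of 48 h, tested at 100 uM; a higher number here means a weaker effect of the compound at the concentration tested, a lower number a stronger effect. Compound 1 `COc1ccc(-c2nc(C)c(C(=O)CSc3nc(N)c(C#N)c(-c4ccc(OC)cc4)n3)s2)cc1` carries methoxyphenyl groups on both arms; in this assay compound 1 gives 0.26%. Compound 2 `Cc1nc(-c2ccc(Cl)cc2)sc1C(=O)CSc1nc(N)c(C#N)c(-c2ccc(Cl)cc2)n1` carries chlorophenyl groups on both arms, and in this assay compound 2 gives 1.65%, the highest of the two numbers, though the gap to compound 1 lies within the usual scatter of this measurement, so the two values show no real difference.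

Compound 3 `COc1ccc(-c2nc(SCC(=O)c3sc(-c4ccc(Cl)cc4)nc3C)nc(N)c2C#N)cc1` has not yet been measured. It differs from compound 2 at one place: methoxy in place of chloro on an aromatic carbon. The exchange sits on an aromatic carbon of a six-membered aromatic ring of carbon only, para to a large group, so compound 3 carries one chlorophenyl and one methoxyphenyl.

Since compound 1 with two methoxy groups gives 0.26% and compound 2 with two chloro groups gives 1.65%, both small numbers, no step beyond the scatter is expected from compound 2 to compound 3, estimated as a number 0.7 percentage points lower from compound 2 to compound 3 (within the scatter). Compound 3 is expected to give about 1%, likely between 0.1% and 8%.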

Compound 3, a percentage reported as activity, at one concentration (the size of the read-out at that concentration, not a potency): 0.79%
Beside the measured number, compound 3's estimate is 0.2 percentage points above it; the measured number falls inside the stated range.
By their numbers in this assay, from the lowest: compounds 1, 3 and 2 (each within the scatter of the next).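

In this assay, replacing 4-chlorophenyl with 4-methoxyphenyl on one arm gives a number 0.9 percentage points lower from compound 2 to compound 3 (within the scatter) and the opposite exchange on the other arm gives a number 0.5 percentage points higher from compound 1 to compound 3 (within the scatter) so each arm can now be judged on its own. Compound 1 and compound 2 differ in two places and could not show this, whereas compound 3 shows that neither single exchange of chloro and methoxy on an aromatic carbon moves the number beyond the scatter. Nothing available explains this result. All three compounds were compared at one concentration, so this read-out cannot show whether their potencies differ. On these data alone, it also remains open whether an amine, a carboxylic acid or a longer chain at this place would change the number beyond the scatter.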